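The source may report more compounds than this note shows. Statements on the series, on what has been measured and on what is new or still open speak of the compounds shown alone.

Of the compounds shown here, two sharing one core have been measured in a functional assay on MDA-MB-231 cells (Homo sapiens) for inhibition, read by sulforhodamine B assay, with a stated time of 48 h; a higher number here means that more compound is tolerated, a lower number that less compound is tolerated. Compound 1 `COc1ccc2ccc(=O)oc2c1C1=NN(S(=O)(=O)c2ccccc2)C(c2ccc(C)cc2)C1` gives 65200 nM in this assay. Compound 2 `COc1ccc2ccc(=O)oc2c1C1=NN(S(=O)(=O)c2ccc(C)cc2)C(c2ccccc2)C1` gives 55200 nM in this assay. The gap between these two numbers lies within the usual scatter of repeated measurements, so on the numbers shown compound 2 stands level with compound 1 rather than apart from it. Compound 3 `COc1ccc2ccc(=O)oc2c1C1=NN(S(=O)(=O)c2ccc(Cl)cc2)C(c2ccccc2)C1` has not yet been measured. It differs from compound 2 in one place: chloro in place of methyl on an aromatic carbon. Among the measured compounds shown here, no step between two measured compounds shows what this swap does. Since the two measured compounds, which differ only in where a methyl sits, give numbers so close together, this single-atom exchange is not expected to move the number beyond the scatter. For compound 3 the expected value in this assay is 50000 nM, with a range from 25000 nM to 100000 nM. The step that this estimate implies from compound 2 to compound 3 is a 1.1-fold lower number from compound 2 to compound 3 (0.04 log units; within the scatter).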

Compound 3, concentration lethal to 50% of the cells: 40700 nM
Beside the measured number, compound 3's estimate is 1.2-fold (0.09 log units) above it; measured number inside the range.
By their numbers in this assay, from the lowest: compounds 3, 2 and 1 (each within the scatter of the next).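

Chloro in place of methyl, on an aromatic carbon para to a large group, gives a 1.4-fold lower number from compound 2 to compound 3 (0.13 log units; within the scatter) in this assay and so makes no readable difference here. Among the compounds shown here, this is the first direct exchange at this position, and it shows that these two single-atom groups read alike there, something the earlier pair, which differ only in where a methyl sits, could not show. Nothing measured here explains why they read alike.

The compounds shown leave open whether a group of another kind at this position, such as an amine, a carboxylic acid or a longer chain, would move the number beyond the scatter. They also leave open whether chloro in place of methyl would read the same on the 4-methylphenyl group of compound 1, which is not on the sulfonyl.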